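The source may report more compounds than this note shows. Statements on the series, on what has been measured and on what is new or still open speak of the compounds shown alone.

Of the compounds shown here, three built on one shared core have been measured in a functional assay on BJAB cells (Homo sapiens) for antiproliferative activity, with a stated time of 4 days; a lower number here means that less compound is needed, a higher number that more compound is needed for the effect. Compound 1 `COc1ccc(-c2c(C)nn(-c3nc(-c4ccc(Cl)c(Cl)c4)c(SC(C)C)s3)c2C(=O)O)cc1` gives 2100 nM. Compound 2 `CCOc1ncccc1-c1c(C)nn(-c2nc(-c3ccc(Cl)c(Cl)c3)c(SC(C)C)s2)c1C(=O)O` gives 11000 nM, and compound 3 `COc1cc(C#N)cc(-c2c(C)nn(-c3nc(-c4ccc(Cl)c(Cl)c4)c(SC(C)C)s3)c2C(=O)O)c1` gives 5200 nM. Compound 3 therefore stands second highest of the three numbers: its nearest neighbour is compound 2, reached by a 2.1-fold lower number from compound 2 to compound 3 (0.33 log units; beyond the scatter), and the furthest is compound 1, reached by a 2.5-fold higher number from compound 1 to compound 3 (0.39 log units; beyond the scatter). The largest step among the three, still a modest one, is a 5.2-fold higher number from compound 1 to compound 2 (0.72 log units; beyond the scatter).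

Compound 4 `Cc1nn(-c2nc(-c3ccc(Cl)c(Cl)c3)c(SC(C)C)s2)c(C(=O)O)c1-c1cccc(Cl)c1` differs from compound 3 in one place: 3-chlorophenyl in place of 3-cyano-5-methoxyphenyl on an aromatic carbon. All three measured steps exchange the group on that same aromatic carbon, and all three were modest, so the change to compound 4 is expected to be modest as well. The lowest number so far belongs to compound 1, which carries 4-methoxyphenyl on that aromatic carbon, while 3-chlorophenyl has no measured counterpart among these compounds, so the direction is uncertain; a small move toward a lower number is expected, staying inside the spread already seen. Compound 4 is therefore expected to give about 3500 nM in this assay, within a range from 1200 nM to 10000 nM, which is expected to amount to a step of a 1.5-fold lower number from compound 3 to compound 4 (0.17 log units; within the scatter).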

Compound 4, half-maximal effective concentration: 13600 nM
For compound 4 the middle estimate is 3.9-fold (0.59 log units) below the measured one, outside the stated range (above it).
By their numbers in this assay, from the lowest: compound 1; then compound 3; then compounds 2 and 4 (each within the scatter of the next).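

In this assay, 3-chlorophenyl on this aromatic carbon of the five-membered ring gives a 2.6-fold higher number from compound 3 to compound 4 (0.42 log units; beyond the scatter) as the step from the nitrile-bearing group, and a 6.5-fold higher number from compound 1 to compound 4 (0.81 log units; beyond the scatter) as the step from 4-methoxyphenyl, the widest spread yet seen at this position, so all three replacements of 4-methoxyphenyl shown here give higher numbers and none of the compounds goes against that. The comparison with the pyridine-bearing compound gives a 1.2-fold higher number from compound 2 to compound 4 (0.09 log units; within the scatter) as its step, so 3-chlorophenyl and 2-ethoxypyridin-3-yl cannot be told apart in this assay even though they differ in ring atoms and in their substituents. Nothing shown here offers a measured explanation for these differences at this position.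

The compounds shown leave open whether the low number of compound 1 depends on the methoxy group itself or on where it sits on the phenyl ring, a question that 3-methoxyphenyl and 4-chlorophenyl at this carbon would address. They also leave open how this position would respond to an unsubstituted phenyl or to a phenyl ring bearing an amine.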